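Benzyl to benzoyl on a compound beyond the limit

This account rests on a few compounds, and the source may have more. Where it says the series, first, only, none or still open, it means among the compounds named here.

In an assay on isolated protein with Bile acid receptor (Homo sapiens) as the target (on this read-out lower numbers stand for an effect already at smaller amounts and higher numbers for an effect only at larger amounts of compound), compound 1 `COC(=O)/C=C/c1cccc(N(Cc2ccc(/C=C/c3c(F)cccc3F)cc2)C(=O)C(C)C)c1` gives 108 nM, and compound 2 `COC(=O)/C=C/c1cccc(N(Cc2ccc(/C=C/C(=O)OC(C)(C)C)cc2)C(=O)NC(C)C)c1` gives 212 nM. Compound 3 `COC(=O)/C=C/c1cccc(N(Cc2ccc(/C=C/C(=O)OC(C)(C)C)cc2OCc2ccccc2)C(=O)C2CCCCC2)c1` is reported in this assay only as a limit, > 1000 nM. That limit is the limit of > 1000 nM in this assay, at which 1 of the 3 values shown sits, so compound 3 carries no numerical value on the scale shown. Compound 4 `COC(=O)/C=C/c1cccc(N(Cc2ccc(/C=C/C(=O)OC(C)(C)C)cc2OC(=O)c2ccccc2)C(=O)C2CCCCC2)c1` differs from compound 3 by benzoyl in place of benzyl on an oxygen on an aromatic ring. Going by the values given here, no measured pair isolates this single change, so the expectation for compound 4 rests on the position of compound 3 at the limit. The step is expected to be a step that the limit leaves unreadable from compound 3 to compound 4, with no movement beyond the scatter. Compound 4 is therefore expected to give about 1500 nM in this assay, within a range from 400 nM to 6000 nM, and it may again be reported only as a limit.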

Compound 4, half-maximal effective concentration: > 1000 nM
Compound 4 ended at the assay's limit; the forecaster's own chance of this, stated with the estimate: 55%; the middle value is on the limit's open side.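

No step can be read between compound 3 and compound 4, as both are reported only as limits: the limit of > 1000 nM in this assay, at which 2 of the 4 values shown sit.

The compounds shown leave open what benzoyl in place of benzyl on an oxygen on an aromatic ring does on a compound with a numerical value.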